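A few compounds are considered here, and "the series" means these few. Any claim that something is new, unique, unknown or untested is made for them only; others in the source may bear on it.

Measured compounds:
- compound 1 `CC1CCN(C2CCN(S(=O)(=O)c3cccc(Br)c3)CC2)CC1`: 3.2 nM
- compound 2 `COc1ccccc1-c1cccc(S(=O)(=O)N2CCC(N3CCC(C)CC3)CC2)c1`: 21 nM
- compound 3 `CC1CCN(C2CCN(S(=O)(=O)c3cccc(-c4ccc(F)cc4)c3)CC2)CC1`: 12 nM

In a functional assay on DLD-1 cells (Homo sapiens) for antiproliferative activity, read by CellTiter-Glo, with a stated time of 72 h (on this read-out lower numbers stand for stronger inhibition and higher numbers for weaker inhibition), compound 1 gives the lowest of the three numbers and is the most potent of the set, since both steps away from it lie beyond the scatter: a 3.8-fold higher number from compound 1 to compound 3 (0.57 log units; beyond the scatter) and a 6.6-fold higher number from compound 1 to compound 2 (0.82 log units; beyond the scatter). Between the other two, a 1.8-fold lower number from compound 2 to compound 3 (0.24 log units; within the scatter).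

Compound 4 `CC1CCN(C2CCN(S(=O)(=O)c3nccn3C)CC2)CC1` differs from compound 1 in one place: 1-methyl-1H-imidazol-2-yl in place of 3-bromophenyl on a sulfonyl sulfur. Going by the values given here, no measured step replaces the whole aromatic group on the sulfonyl sulfur, so the comparison is indirect. The two measured steps from compound 1 each exchanged only the bromo substituent and both raised the number modestly. A modest rise, with wide uncertainty, is therefore expected for compound 4 in this assay, a step of a 9.4-fold higher number from compound 1 to compound 4 (0.97 log units; beyond the scatter). Compound 4 is estimated at 30 nM, in the range 5 nM to 200 nM.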

Compound 4, half-maximal inhibitory concentration: > 5000 nM
Compound 4: only a limit was reported (the forecaster's own chance of this, stated with the estimate: 5%); middle value at least 160-fold (2.22 log units) away from the limit.
By their numbers in this assay, from the lowest: compound 1; then compounds 3 and 2 (each within the scatter of the next). At a limit, above all of these: compound 4.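

In this assay, replacing the whole 3-bromophenyl group on the sulfonyl sulfur with 1-methyl-1H-imidazol-2-yl gives an at least 1500-fold higher number from compound 1 to compound 4 (3.19 log units; beyond the scatter), a large step where the exchanges of the bromo substituent alone were modest. This step rests on a limit and not on a number for compound 4: the limit of > 5000 nM in this assay, at which 1 of the 4 values shown sits. The position therefore does not accept every aromatic group, although compounds 1, 2 and 3, which all keep the phenyl ring, remain active.

The compounds shown do not separate the five-membered ring, its nitrogen atoms and the lost bromo as sources of this loss. A plain phenyl or a pyridyl group on the sulfonyl sulfur would bear on that question.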